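The source may report more compounds than this note shows. Statements on the series, on what has been measured and on what is new or still open speak of the compounds shown alone.

In a functional assay on HepG2 cells (Homo sapiens) for inhibition, read by MTT assay, with a stated time of 48 h (a higher number here means a weaker inhibitor, a lower number a stronger inhibitor), compound 1 `COc1ccc(CSc2nnc(-c3cc(OC)c(OC)c(OC)c3)n2-c2ccc(OC)cc2)cc1` gives 41100 nM. The value for compound 2 `COc1ccc(-n2c(SCC(=O)c3ccc4ccccc4c3)nnc2-c2cc(OC)c(OC)c(OC)c2)cc1`, > 60000 nM, is a limit of the assay. Compound 3 `COc1ccc(-n2c(SCC(=O)Nc3ccc(Cl)cc3)nnc2-c2cc(OC)c(OC)c(OC)c2)cc1` carries (4-chlorophenyl)amino in place of naphthalen-2-yl on a carbonyl carbon. Among the compounds with values here, the only measured step that bears on this change is an at least 1.4-fold higher number from compound 1 to compound 2 (0.16 log units; that floor lies within the scatter). Its floor lies within the scatter, and it concerns a different swap, so it offers only weak guidance. No change beyond the scatter is therefore expected, and the estimated step is an at least 1.3-fold lower number from compound 2 to compound 3 (0.12 log units; that floor lies within the scatter). Compound 3 is expected to give about 45000 nM, with an estimated range of 15000 nM to 100000 nM.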

Compound 3, half-maximal inhibitory concentration: > 60000 nM
Compound 3: a limit, no number; the forecaster's own chance of this, stated with the estimate: 40%; at least 1.3-fold (0.12 log units) between middle value and limit.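

In this assay compound 3 gives > 60000 nM, which is a limit of the assay and not a number. Putting (4-chlorophenyl)carbamoyl in place of 4-methoxyphenyl on the saturated chain carbon bound to a sulfur gives an at least 1.4-fold higher number from compound 1 to compound 3 (0.16 log units; that floor lies within the scatter). The step between compound 2 and compound 3 cannot be read, because both compounds sit at the same limit: the limit of > 60000 nM in this assay, at which 2 of the 3 values shown sit.

Going by these compounds, whether any group on this carbonyl carbon gives a readable number stays open. A hydroxyl, which would make a carboxylic acid, or a small amine such as dimethylamino could be informative there.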